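Chain lengthening on the ester of the shared core

The source may hold more compounds than are shown below. What is called first, only, known or untested is meant among the compounds shown, and "the series" means these compounds.

Measured in a functional assay on A549 cells (Homo sapiens) for cytotoxicity, read by MTT assay, with a stated time of 24 h, tested at 80 uM; a lower number here means a stronger effect, a higher number a weaker effect of the compound at the concentration tested:
compound 1 `CCCCOC(=O)CCC(=O)N1CCN(CCCOc2cc3c(Nc4ccc(F)c(Cl)c4)ncnc3cc2OC)CC1` gives 36.9%
compound 2 `CCCCCCCCCOC(=O)CCC(=O)N1CCN(CCCOc2cc3c(Nc4ccc(F)c(Cl)c4)ncnc3cc2OC)CC1` gives 7.8%
compound 3 `CCCCCCCCCCOC(=O)CCC(=O)N1CCN(CCCOc2cc3c(Nc4ccc(F)c(Cl)c4)ncnc3cc2OC)CC1` gives 2%

Compound 3 gives the lowest of the three numbers in this assay; its nearest neighbour is compound 2, with a gap within the scatter, so the two cannot be set apart, while compound 1 stands furthest away, beyond the scatter. The step of a number 34.9 percentage points lower from compound 1 to compound 3 (beyond the scatter) is large and the step of a number 29.1 percentage points lower from compound 1 to compound 2 (beyond the scatter) is modest, whereas the step of a number 5.8 percentage points lower from compound 2 to compound 3 (within the scatter) lies within the scatter.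

Compound 4 `CCCCCCCCCCCOC(=O)CCC(=O)N1CCN(CCCOc2cc3c(Nc4ccc(F)c(Cl)c4)ncnc3cc2OC)CC1` differs from compound 3 in one place: methyl in place of hydrogen on a saturated chain carbon, ten or more bonds along the chain from an oxygen next to a carbonyl group. The step that bears most directly on this change is the one-carbon step a number 5.8 percentage points lower from compound 2 to compound 3 (within the scatter), which stayed within the scatter; the larger steps from compound 1 show that the bigger lengthenings moved the number down beyond the scatter, but compound 3 already stands close to the bottom of the readable range. One further carbon on an already long chain is therefore expected to change the number in this assay by nothing beyond the scatter. Compound 4 is expected to give 2%, between 0% and 9%. The step this estimate means, no change at the digits printed from compound 3 to compound 4 (within the scatter), is expected to remain within the scatter.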

Compound 4, a percentage reported as activity, at one concentration (the size of the read-out at that concentration, not a potency): 2.8%
Compound 4: the middle estimate sits 0.8 percentage points below what was measured, within the range that was stated.
By their numbers in this assay, from the lowest: compounds 3, 4 and 2 (each within the scatter of the next); then compound 1.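

Working notes on the ester chain: in this assay, methyl in place of hydrogen on a saturated chain carbon, ten or more bonds along the chain from an oxygen next to a carbonyl group, gives a number 0.8 percentage points higher from compound 3 to compound 4 (within the scatter), and the ethyl difference gives a number 5 percentage points lower from compound 2 to compound 4 (within the scatter), so compound 2, compound 3 and compound 4 cannot be set apart at this concentration. For the compounds shown here, the heptyl difference still gives a number 34.1 percentage points lower from compound 1 to compound 4 (beyond the scatter), which places the one change beyond the scatter between compound 1 and the three longer-chain compounds, with no readable change among those three and no compound among the four going against this. No data on any property of these compounds bear on this result.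

Still open, on these data alone, is how the read-out behaves for chains of intermediate length between compound 1 and compound 2, where the whole of the large step lies. Also open, as far as these compounds go, is whether a longer chain, or a chain ending in an amine or a carboxylic acid, would leave this assay as low as compound 4, and a single-concentration read-out this close to the bottom of its range could not show any further gain.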